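Swapping the benzyl group for a branched phenylpropyl

This account rests on a few compounds, and the source may have more. Where it says the series, first, only, none or still open, it means among the compounds named here.

Compound 1 `C/C(=C\C(=O)Nc1ccccc1OCCCC(=O)O)c1ccc2c(ccn2Cc2ccc(F)cc2)c1` gives 97 nM in an assay on Prostate gland for inhibition of steroid 5-alpha-reductase (Rattus norvegicus); on this read-out lower numbers stand for stronger inhibition and higher numbers for weaker inhibition. Compound 2 `C/C(=C\C(=O)Nc1ccccc1OCCCC(=O)O)c1ccc2c(ccn2Cc2ccc(C(C)(C)C)cc2)c1` gives 170 nM. Compound 2 has the higher of the two numbers, but the step of a 1.8-fold higher number from compound 1 to compound 2 (0.24 log units; within the scatter) lies within the scatter, so the two compounds cannot be told apart. Compound 3 `CCC(c1ccccc1)n1ccc2cc(/C(C)=C/C(=O)Nc3ccccc3OCCCC(=O)O)ccc21` differs from compound 2 by 1-phenylpropyl in place of 4-(tert-butyl)benzyl on an aromatic nitrogen. Among the compounds with values here, the only measured step also changed this group on the aromatic nitrogen and stayed within the scatter, so no step beyond the scatter is expected. The estimate for compound 3 is therefore 200 nM (range 60 nM to 700 nM), a step of a 1.2-fold higher number from compound 2 to compound 3 (0.07 log units; within the scatter).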

Compound 3, half-maximal inhibitory concentration: 19 nM
Compound 3: the middle estimate sits 11-fold (1.02 log units) above what was measured; the whole stated range lies above it.
By their numbers in this assay, from the lowest: compound 3; then compounds 1 and 2 (each within the scatter of the next).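

In this assay, the group on the aromatic nitrogen proves able to move the number beyond the scatter: 1-phenylpropyl gives a lower number than 4-(tert-butyl)benzyl (an 8.9-fold lower number from compound 2 to compound 3 (0.95 log units; beyond the scatter)) and than 4-fluorobenzyl (a 5.1-fold lower number from compound 1 to compound 3 (0.71 log units; beyond the scatter)). Exchanging the ring substituent on the benzyl group had not shown this, since that step stayed within the scatter. Nothing available explains the gain.

Compound 3 differs from compound 1 and compound 2 both in its propyl branch and in lacking a ring substituent, so the contribution of each remains unresolved. A plain benzyl or a 1-phenylethyl group would help separate them.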